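A few compounds are considered here, and "the series" means these few. Any claim that something is new, unique, unknown or untested is made for them only; others in the source may bear on it.

Measured in an ADME assay on HepG2 cells (Homo sapiens) for cytotoxicity, read by luminescence, with a stated time of 72 h (a higher number here means that more compound is needed for the effect, a lower number that less compound is needed), so far:
Compound 1 `CCOC(=O)c1c(-c2cccc(OC)c2)[nH]c2cc(OC(C)C)ccc2c1=O` gives > 21500 nM as a limit
Compound 2 `CCOC(=O)c1c(-c2cccc(OC)c2)[nH]c2cc(OC(F)(F)F)ccc2c1=O` gives > 21500 nM as a limit
Compound 3 `CCOC(=O)c1c(-c2cccc(OC)c2)[nH]c2cc(C(F)(F)F)ccc2c1=O` gives > 21500 nM as a limit

Compound 3 has no number and stands at the limit of > 21500 nM in this assay, at which 3 of the 3 values shown sit. Compound 4 `CCOC(=O)c1c(-c2cccc(Cl)c2)[nH]c2cc(C(F)(F)F)ccc2c1=O` carries chloro in place of methoxy on an aromatic carbon, meta to a large group (chloro in place of methoxy on an aromatic carbon). The measured steps are a step that the two limits leave unreadable from compound 1 to compound 2 and a step that the two limits leave unreadable from compound 1 to compound 3 and a step that the two limits leave unreadable from compound 2 to compound 3. All three change another group, so they give no size for this change. Since compound 3 holds the limit > 21500 nM no step beyond the scatter is expected in this assay in either direction. The estimated step is an at least 1.0-fold lower number from compound 3 to compound 4 (0.03 log units; that floor lies within the scatter). For compound 4 the expected value is 20000 nM with an estimated range from 9000 nM to 40000 nM.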

Compound 4, half-maximal effective concentration: > 21500 nM
Compound 4 ended at the assay's limit; the forecaster's own chance of this, stated with the estimate: 80%; at least 1.0-fold (0.03 log units) between middle value and limit.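

No step can be read between compound 3 and compound 4, since both stand at a limit and not at a number: the limit of > 21500 nM in this assay, at which 4 of the 4 values shown sit.

The compounds shown leave open whether chloro in place of methoxy changes the value at all.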